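This account rests on a few compounds, and the source may have more. Where it says the series, first, only, none or still open, it means among the compounds named here.

Of the compounds shown here, three have so far been tested in a functional assay on SW-620 cells (Homo sapiens) for inhibition, read by MTT assay, with a stated time of 48 h; on this read-out lower numbers stand for stronger inhibition and higher numbers for weaker inhibition. Compound 1 `Cc1ccc(COc2ccc(C(=O)NC(=S)Nc3ccc(C)c(-c4nc5ccccc5[nH]4)c3)cc2)cc1` gives 60900 nM, compound 2 `Cc1ccc(NC(=S)NC(=O)c2ccc(OCc3ccc(Cl)c(Cl)c3)cc2)cc1-c1nc2ccccc2[nH]1` gives 30700 nM, and compound 3 `Cc1ccc(NC(=O)NC(=O)c2ccc(OCc3cccc(C(F)(F)F)c3)cc2)cc1-c1nc2ccccc2[nH]1` gives 9640 nM. Compound 3 stands lowest of the three numbers; compound 2 is nearest to it and compound 1 furthest, and both of those gaps lie beyond the scatter. Compound 4 `Cc1ccc(NC(=O)NC(=O)c2ccc(OCc3ccccc3Cl)cc2)cc1-c1nc2ccccc2[nH]1` has not yet been measured. It differs from compound 3 in one place: 2-chlorophenyl in place of 3-(trifluoromethyl)phenyl on a saturated chain carbon bound to an oxygen on an aromatic ring. Going by the values given here, only one measured step touches the same place, the change on the saturated chain carbon bound to an oxygen on an aromatic ring from compound 1 to compound 2, which gave a 2.0-fold lower number from compound 1 to compound 2 (0.30 log units; within the scatter). Among the compounds with values here, compound 3 and compound 4 differ from compound 1 and compound 2 elsewhere as well, so that single step is the only guide. On that basis the swap is expected to move this assay little, if at all, and the estimated step of a 1.0-fold higher number from compound 3 to compound 4 (0.02 log units; within the scatter) is expected to stay within the scatter. Compound 4 is therefore estimated at 10000 nM, with an expected range from 4000 nM to 25000 nM.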

Compound 4, half-maximal inhibitory concentration: 35700 nM
The estimate for compound 4 lay 3.6-fold (0.55 log units) below the measured number; the whole stated range lies below it.
By their numbers in this assay, from the lowest: compound 3; then compounds 2, 4 and 1 (each within the scatter of the next).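

In this assay the group on the saturated chain carbon bound to an oxygen on an aromatic ring now proves able to move the read-out: 2-chlorophenyl in place of 3-(trifluoromethyl)phenyl gives a 3.7-fold higher number from compound 3 to compound 4 (0.57 log units; beyond the scatter) in a pair otherwise alike. Going by these compounds alone, the only earlier change at this place, a 2.0-fold lower number from compound 1 to compound 2 (0.30 log units; within the scatter) with 3,4-dichlorophenyl in place of 4-methylphenyl, stayed within the scatter, so the two steps show that this place does not answer alike to every swap, though they involve different groups and different surroundings. No measurement at hand bears on why this swap raises the number. As far as these compounds go, what remains open is whether the chlorine itself, its place on the ring or the loss of the trifluoromethyl group carries the step, since all of these change together between the two compounds, and whether the same swap would read alike in the sulfur-bearing compounds. From the compounds shown here alone, it also remains open how this place would answer to a phenyl ring carrying an amine or a carboxylic acid instead of a halogen.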